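Trading 2,4-dimethylphenyl for 4-methoxyphenyl on a carbonyl carbon

A few compounds are considered here, and "the series" means these few. Any claim that something is new, unique, unknown or untested is made for them only; others in the source may bear on it.

- compound 1 `COc1ccc(/C=C/c2cc(OC)cc(OC)c2/C=C/C(=O)c2ccc(N)cc2)cc1` gives 3.8 ug/mL
- compound 2 `COc1ccc(/C=C/c2cc(OC)cc(OC)c2/C=C/C(=O)c2ccccc2C)cc1` gives 5.9 ug/mL
- compound 3 `COc1ccc(/C=C/c2cc(OC)cc(OC)c2/C=C/C(=O)c2ccc(C)cc2C)cc1` gives 0.3 ug/mL

All three numbers come from a functional assay on A549 cells (Homo sapiens) for antiproliferative activity, read by MTT assay, with a stated time of 48 h (on this read-out lower numbers stand for stronger inhibition and higher numbers for weaker inhibition), and there compound 3, at 0.3 ug/mL, is the strongest of the three. The next compound, compound 4 `COc1ccc(/C=C/c2cc(OC)cc(OC)c2/C=C/C(=O)c2ccc(OC)cc2)cc1`, keeps the shared core but has 4-methoxyphenyl in place of 2,4-dimethylphenyl on a carbonyl carbon.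

Among the compounds with values here, three measured steps bear on this swap. Two of them end at the 2,4-dimethylphenyl group and are large: a 13-fold lower number from compound 1 to compound 3 (1.10 log units; beyond the scatter) and a 20-fold lower number from compound 2 to compound 3 (1.29 log units; beyond the scatter). The second of these is only methyl in place of hydrogen on an aromatic carbon. The third, a 1.6-fold higher number from compound 1 to compound 2 (0.19 log units; within the scatter), shows the two compounds without that group staying close together. Within the data shown here, compound 4 also lacks the group, so a clearly higher number is expected, though no methoxy compound has yet been measured. The expected change is a 10-fold higher number from compound 3 to compound 4 (1.00 log units; beyond the scatter), somewhat smaller than those two large steps. For compound 4 the estimated value is 3 ug/mL, with an expected range from 0.8 ug/mL to 9 ug/mL.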

Compound 4, half-maximal inhibitory concentration: 4.5 ug/mL
Beside the measured number, compound 4's estimate is 1.5-fold (0.18 log units) below it; measured number inside the range.
By their numbers in this assay, from the lowest: compound 3; then compounds 1, 4 and 2 (each within the scatter of the next).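

In this assay the swap to 4-methoxyphenyl on a carbonyl carbon brings a 15-fold higher number from compound 3 to compound 4 (1.18 log units; beyond the scatter), so the low number of compound 3 does not carry over to this group. The new compound instead joins the two other compounds without the 2,4-dimethylphenyl group, with a 1.3-fold lower number from compound 2 to compound 4 (0.12 log units; within the scatter) and a 1.2-fold higher number from compound 1 to compound 4 (0.07 log units; within the scatter), which leaves 2-methylphenyl, 4-aminophenyl and 4-methoxyphenyl indistinguishable here while compound 3 stands apart from all of them. Nothing measured here explains why the 2,4-dimethylphenyl group stands apart. Still open is whether the low number needs both methyl groups, since a 4-methylphenyl group on its own is not among the compounds shown. A 2,4-dimethoxyphenyl group would likewise show whether two substituents of another kind can do the same.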